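Bromo in place of nitro in an antiproliferative set

The source may hold more compounds than are shown below. What is called first, only, known or untested is meant among the compounds shown, and "the series" means these compounds.

Compound 1 `C/C(=N\O)c1ccc(OCc2ccc(C(=O)NO)cc2)cc1` gives "not determined" (no result reported) 
Compound 2 `Nc1ccccc1NC(=O)c1ccc(COc2ccc([N+](=O)[O-])cc2)cc1` gives > 32000 nM 

For the measured compounds named here, in a functional assay on MGC-803 cells (Homo sapiens) for antiproliferative activity, read by CCK-8 assay, with a stated time of 72 h (on this read-out higher numbers stand for weaker inhibition and lower numbers for stronger inhibition), compound 1 has no result, so compound 2 supplies the only reading. That reading is a limit of the assay and not a number, and it stands as the limit of > 32000 nM in this assay, at which 1 of the 2 values shown sits, in the record of these two compounds.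

Compound 3 `Nc1ccccc1NC(=O)c1ccc(COc2ccc(Br)cc2)cc1` has yet to be measured. It keeps the rest of compound 2 and carries bromo in place of nitro on an aromatic carbon, para to a large group: bromo in place of nitro on an aromatic carbon. Going by the values given here, no step between measured compounds is available to size this change, so any expectation is a cautious one. In this assay a modest move towards stronger inhibition is expected, and the reading may again turn out to be only a limit. The estimated change is an at least 2.1-fold lower number from compound 2 to compound 3 (0.32 log units; beyond the scatter) and it carries wide uncertainty. Compound 3 is estimated at 15000 nM in the expected range from 4000 nM to 45000 nM for this measurement.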

Compound 3, half-maximal inhibitory concentration: > 32000 nM
Compound 3 was reported as a limit; the forecaster's own chance of this, stated with the estimate: 45%; at least 2.1-fold (0.32 log units) between middle value and limit.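

In this assay compound 2 and compound 3 both stand as limits of the assay and not as numbers, so no step between them can be read: the limit of > 32000 nM in this assay, at which 2 of the 3 values shown sit.

The compounds shown leave open whether bromo in place of nitro on the aromatic carbon changes inhibition at all.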